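From dimethylamino to 4-methylpiperazin-1-yl on the shared core

The source may hold more compounds than are shown below. What is called first, only, known or untested is meant among the compounds shown, and "the series" means these compounds.

Measured in a functional assay on SK-BR-3 cells (Homo sapiens) for antiproliferative activity, read by MTT assay, with a stated time of 72 h; on this read-out lower numbers stand for stronger inhibition and higher numbers for weaker inhibition:
Compound 1 `CCN1CCN(c2cc(C)c3cc(NC(=O)c4cccc(C)c4)ccc3n2)CC1`: 13700 nM
Compound 2 `CCN1CCN(c2cc(C)c3cc(NC(=O)c4ccc(Br)cc4)ccc3n2)CC1`: 6310 nM
Compound 3 `Cc1cc(N(C)C)nc2ccc(NC(=O)c3ccc(Cl)c(Cl)c3)cc12`: > 50000 nM

Compound 3 stands at the limit of > 50000 nM in this assay, at which 1 of the 3 values shown sits, so its entry is a limit and not a number. Compound 4 `Cc1cc(N2CCN(C)CC2)nc2ccc(NC(=O)c3ccc(Cl)c(Cl)c3)cc12` keeps the rest of compound 3 but carries 4-methylpiperazin-1-yl in place of dimethylamino on an aromatic carbon, next to the ring nitrogen: 4-methylpiperazin-1-yl in place of dimethylamino on an aromatic carbon.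

For the measured compounds named here, no measured step covers this exchange directly. The only one, a 2.2-fold lower number from compound 1 to compound 2 (0.34 log units; beyond the scatter), is modest and concerns the group on the carbonyl carbon, so it indicates only how far such a change moved the number. The nearer guide is that compound 1 and compound 2, which bear a close relative of the entering group at that place, both gave numbers. Compound 1 reads 13700 nM, and compound 2 reads 6310 nM. A clear move towards stronger inhibition is therefore expected, though its size is uncertain from a limit. The expected change is an at least 5.0-fold lower number from compound 3 to compound 4 (0.69 log units; beyond the scatter). For compound 4 the estimated value in this assay is 10000 nM, with an expected range of 3000 nM to 40000 nM.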

Compound 4, half-maximal inhibitory concentration: 6320 nM
Estimate against measurement, compound 4: 1.6-fold (0.20 log units) above; the range from low to high includes it.
By their numbers in this assay, from the lowest: compounds 2 and 4 (each within the scatter of the next); then compound 1. At a limit, above all of these: compound 3.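

For the compounds shown here, the earlier step concerned only the group on the carbonyl carbon, whereas this one is the first to show that the group on the aromatic carbon, next to the ring nitrogen, also matters in this assay. Exchanging dimethylamino for 4-methylpiperazin-1-yl while the rest of the molecule stays the same gives an at least 7.9-fold lower number from compound 3 to compound 4 (0.89 log units; beyond the scatter), bringing the read-out from a limit to a measured value. The size of this step is therefore a minimum, not an exact figure, because one end of it is a limit: the limit of > 50000 nM in this assay, at which 1 of the 4 values shown sits.

The compounds shown leave open how far the step truly extends and whether it depends on the ring or on its second nitrogen. A piperidine or morpholine at this place, or a piperazine carrying a free amine, would separate these two features.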